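The source may report more compounds than this note shows. Statements on the series, on what has been measured and on what is new or still open speak of the compounds shown alone.

Compound 1, `Fc1ccccc1COc1ccc(-c2cc(CN3CCN(Cc4ccc(C(F)(F)F)cc4)CC3)no2)cc1`, and compound 2, `Fc1cccc(COc2ccc(-c3cc(CN4CCN(Cc5ccc(C(F)(F)F)cc5)CC4)no3)cc2)c1`, are built on one shared core, while compound 3, `N#Cc1cccc(COc2ccc(-c3cc(CN4CCN(Cc5ccccc5F)CC4)no3)cc2)c1`, and compound 4, `N#Cc1cccc(COc2ccc(-c3cc(CN4CCN(Cc5cccc(F)c5)CC4)no3)cc2)c1`, are built on another; the difference between the two cores is not broken down here. In a functional assay on MCF7 cells (Homo sapiens) for antiproliferative activity, read by sulforhodamine B assay, with a stated time of 72 h (on this read-out lower numbers stand for stronger inhibition and higher numbers for weaker inhibition), compound 1 gives 3000 nM, and compound 2 gives 2500 nM. The change between them is 3-fluorophenyl in place of 2-fluorophenyl on a saturated chain carbon bound to an oxygen on an aromatic ring, and it made a 1.2-fold lower number from compound 1 to compound 2 (0.08 log units; within the scatter). In this assay compound 3 gives 1400 nM, a number that sits within the scatter of compound 2 but clearly lower than that of compound 1.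

Compound 4 has not yet been measured. It differs from compound 3 by 3-fluorophenyl in place of 2-fluorophenyl on a saturated chain carbon bound to an amine nitrogen in a ring. Among the compounds with values here, this is the same kind of change as the one between compound 1 and compound 2, but not the same change: there the place was on a saturated chain carbon bound to an oxygen on an aromatic ring, here it is on a saturated chain carbon bound to an amine nitrogen in a ring. Within the data shown here, the only measured instance of this kind of change moved the number by less than the usual scatter, so compound 4 is expected to move by about a 1.1-fold lower number from compound 3 to compound 4 (0.03 log units; within the scatter), an expectation that rests on a 1.2-fold lower number from compound 1 to compound 2 (0.08 log units; within the scatter). Compound 4 is therefore estimated to give about 1300 nM in this assay, most likely between 600 nM and 2800 nM.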

Compound 4, half-maximal inhibitory concentration: 2400 nM
Compound 4: middle estimate off by 1.8-fold (0.27 log units), on the low side; low and high end bracket the measured number.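

In this assay, putting 3-fluorophenyl in place of 2-fluorophenyl on a saturated chain carbon bound to an amine nitrogen in a ring gives a 1.7-fold higher number from compound 3 to compound 4 (0.23 log units; within the scatter). Set beside the earlier step, where the same swap sits on a saturated chain carbon bound to an oxygen on an aromatic ring, this step gives no firm sign that the outcome depends on the core, as the two steps do not differ by more than repeated measurements could produce: the same change on two cores in this assay, a 1.2-fold lower number (0.08 log units; within the scatter) from compound 1 to compound 2 and a 1.7-fold higher number (0.23 log units; within the scatter) from compound 3 to compound 4, 2.1-fold (0.31 log units) apart, within the scatter of two such steps. This does not show that the change carries over faithfully from one core to another, since only two instances are available, neither step rises above the scatter, and the swap sits at a different place in each, leaving any modest real difference hidden in the noise.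

The compounds shown leave open whether the same swap would give a clearer step beyond the scatter if the fluorine were replaced by a larger group, such as chlorine or methoxy. They also leave open whether the small size of these steps would hold on a further core, for instance one carrying a carboxylic acid on the benzyl ring.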